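Series notes: terminal vinyl replaced by an ester-bearing chain end

The source may hold more compounds than are shown below. What is called first, only, known or untested is meant among the compounds shown, and "the series" means these compounds.

Among the compounds with values here, in an assay (Cricetulus griseus) for inhibition of aldehyde dehydrogenase, mitochondrial (Homo sapiens) (a lower number here means a stronger inhibitor, a higher number a weaker inhibitor), compound 3 `C=CCCCCOc1ccc2c(=O)c(-c3ccc(O)cc3)coc2c1` gives 150 nM, the highest of the three numbers measured so far. Compound 2 `O=C(O)CCCCCCOc1ccc2c(=O)c(-c3ccc(O)cc3)coc2c1` gives 50 nM and compound 1 `O=C(O)CCCCCCCCCCCOc1ccc2c(=O)c(-c3ccc(O)cc3)coc2c1` gives 130 nM. The step of a 1.2-fold higher number from compound 1 to compound 3 (0.06 log units; within the scatter) lies within the scatter, whereas a 3.0-fold higher number from compound 2 to compound 3 (0.48 log units; beyond the scatter) and a 2.6-fold lower number from compound 1 to compound 2 (0.41 log units; beyond the scatter) stand beyond it, both modest.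

Compound 4 `CCOC(=O)CCCCCOc1ccc2c(=O)c(-c3ccc(O)cc3)coc2c1` differs from compound 3 by (ethoxycarbonyl)methyl in place of vinyl on a saturated chain carbon, four bonds along the chain from an oxygen on an aromatic ring. The step that bears most directly on this change is a 3.0-fold higher number from compound 2 to compound 3 (0.48 log units; beyond the scatter), where the chain ending in carboxy reads lower than the chain ending in vinyl. Within the data shown here, compound 4 keeps the chain length of compound 2 but ends in (ethoxycarbonyl)methyl rather than carboxy, and no measured step covers that exchange. The number for compound 4 is therefore expected to fall between the values of compound 2 and compound 3. The expected step is a 1.9-fold lower number from compound 3 to compound 4 (0.27 log units; within the scatter), a modest move down. For compound 4 the estimate in this assay is 80 nM, with a range of 35 nM to 200 nM.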

Compound 4, half-maximal inhibitory concentration: 280 nM
Estimate against measurement, compound 4: 3.5-fold (0.54 log units) below; measured number above the stated range.
By their numbers in this assay, from the lowest: compound 2; then compounds 1, 3 and 4 (each within the scatter of the next, the first and the last beyond it).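

Working notes: in this assay, the ester end does not read like the carboxy end at similar chain length, since a 5.6-fold higher number from compound 2 to compound 4 (0.75 log units; beyond the scatter) is the widest listed step in the series. The longer carboxy chain points the same way, with a 2.2-fold higher number from compound 1 to compound 4 (0.33 log units; beyond the scatter) also beyond the scatter, but compound 1 and compound 3 sit within the scatter of each other, so a carboxy end alone does not set the number. Exchanging vinyl for (ethoxycarbonyl)methyl gives no separable change, as a 1.9-fold higher number from compound 3 to compound 4 (0.27 log units; within the scatter) stays within the scatter, and nothing on hand explains these readings.

Open, from the compounds shown here alone, is how an amide or a primary alcohol at the chain end would read. Also open, going by these compounds, is how the ethoxycarbonyl end would read on a longer chain like that of compound 1.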